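The compounds below may be only part of what the source reports. "The series", "measured", "known", "first", "only" and "open" are said of these compounds alone.

Compound 1 `Oc1ccc(-c2cc(-c3ccccc3)cc(-c3cccs3)n2)cc1` gives 1700 nM in a functional assay on HL-60 cells (Homo sapiens) for cytotoxicity, read by ELISA, with a stated time of 2 days; on this read-out higher numbers stand for weaker inhibition and lower numbers for stronger inhibition. Compound 2 `Oc1ccc(-c2cc(-c3ccccc3)cc(-c3ccsc3)n2)cc1` differs from compound 1 by thiophen-3-yl in place of thiophen-2-yl on an aromatic carbon; in this assay compound 2 gives 3600 nM, a step of a 2.1-fold higher number from compound 1 to compound 2 (0.33 log units; beyond the scatter). Compound 3 `Oc1cccc(-c2cc(-c3ccccc3)nc(-c3cccs3)c2)c1` carries a different core; the difference between the two cores is not broken down here. In this assay compound 3 gives 18900 nM, the highest of the three numbers. Compound 4 `Oc1cccc(-c2cc(-c3ccccc3)nc(-c3ccsc3)c2)c1` differs from compound 3 by thiophen-3-yl in place of thiophen-2-yl on an aromatic carbon, the same kind of change as that from compound 1 to compound 2, though here the place is meta to a 3-hydroxyphenyl group rather than meta to a 4-hydroxyphenyl group. For compound 4 the expected step is a 2.0-fold higher number from compound 3 to compound 4 (0.30 log units; within the scatter), resting on a 2.1-fold higher number from compound 1 to compound 2 (0.33 log units; beyond the scatter) and allowing for the wider scatter of high numbers. Compound 4 is therefore estimated at 38000 nM in this assay, with a likely range from 15000 nM to 95000 nM.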

Compound 4, half-maximal inhibitory concentration: 12000 nM
The estimate for compound 4 lay 3.2-fold (0.50 log units) above the measured number; measured number outside the range, below it.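

In this assay the change gives a 1.6-fold lower number from compound 3 to compound 4 (0.20 log units; within the scatter) on the second core, a step that cannot be told from scatter. The step seen on the first core therefore does not carry over to the second: the same change on two cores in this assay, a 2.1-fold higher number (0.33 log units; beyond the scatter) from compound 1 to compound 2 and a 1.6-fold lower number (0.20 log units; within the scatter) from compound 3 to compound 4, 3.3-fold (0.52 log units) apart, beyond the scatter of two such steps.
This rests on a single pair per core: it shows that the step depends on the core among these four compounds, but not which difference between the cores matters or how the step would read on any other core.

Going by these compounds, whether thiophen-3-yl and thiophen-2-yl can be told apart on further cores stays open. Also open, on these data alone, is how an amine or a carboxylic acid in place of the hydroxyl group, or a furan in place of either thiophene, would read on either core.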